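Methyl on the ring nitrogen: from compound 2 to compound 4

This account rests on a few compounds, and the source may have more. Where it says the series, first, only, none or still open, it means among the compounds named here.

Three compounds sharing one core were examined in an ADME assay on microsomes from liver (Mus musculus) for metabolic stability, with a stated time of 30 min; a lower number here means that less of the compound is left, a higher number that more of the compound is left. Compound 2 `N#Cc1ccc(NCc2cc3cc(Cl)ccc3[nH]c2=O)c(=O)[nH]1` stands highest of the three: in this assay compound 2 gives 86%. Compound 1 `Cn1c(C(F)(F)F)ccc(NCc2cc3cc(Cl)ccc3[nH]c2=O)c1=O`, which carries a methyl on the ring nitrogen and a trifluoromethyl group, lies lower, beyond the scatter, and in this assay compound 1 gives 67%. Compound 3 `O=c1[nH]c2ccc(Cl)cc2cc1CNc1cccn(C2CC2)c1=O` lies far below both, and in this assay compound 3 gives 7%. No two of these compounds differ in just one place, so none of these gaps can be tied to a single change.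

Compound 4 `Cn1c(C#N)ccc(NCc2cc3cc(Cl)ccc3[nH]c2=O)c1=O` has not been measured. It differs from compound 2 by methyl in place of hydrogen on an aromatic nitrogen. Since compound 1, which also bears a methyl on the ring nitrogen, gives 67%, compound 4 is expected to lose some of what compound 2 retains, with a step of a number 21 percentage points lower from compound 2 to compound 4 (beyond the scatter) that reaches beyond the scatter. Compound 4 is therefore estimated at 65%, within a range from 40% to 85%.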

Compound 4, percent of the compound remaining: 73%
Compound 4: the middle estimate sits 8 percentage points below what was measured; measured number inside the range.
By their numbers in this assay, from the lowest: compound 3; then compounds 1 and 4 (each within the scatter of the next); then compound 2.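

Within the data shown here, the step from hydrogen to methyl gives the first reading of a single change on this aromatic nitrogen in this assay: a number 13 percentage points lower from compound 2 to compound 4 (beyond the scatter). Among these compounds, the change is modest, yet it shows that this position responds to methyl when the cyano group stays in place, something the earlier compounds, which all differed in more than one place, could not show. With methyl on the nitrogen, cyano in place of trifluoromethyl on the aromatic carbon gives a number 6 percentage points higher from compound 1 to compound 4 (within the scatter), so these two groups cannot be told apart in this setting. Nothing measured here explains the methyl step.

Going by these compounds, it remains open whether a longer chain, such as ethyl, on the aromatic nitrogen would give a larger step than methyl. On these data alone, it is also open how an amine or a carboxylic acid in place of cyano on the aromatic carbon would read in this assay.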